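The source may report more compounds than this note shows. Statements on the series, on what has been measured and on what is new or still open speak of the compounds shown alone.

In a functional assay on HCT-116 cells (Homo sapiens) for cytotoxicity, read by CellTiter-Glo, with a stated time of 5 days (a higher number here means a weaker inhibitor, a lower number a stronger inhibitor), compound 3 `Cc1cc(Nc2nn(C)c(=O)c3ccccc23)n[nH]1` gives 5200 nM, the highest of the three numbers recorded and the weakest inhibitor among them. Compound 1 `COc1ccc(-n2nc(Nc3cc(C)[nH]n3)c3ccccc3c2=O)cc1` gives 700 nM in this assay, and compound 2 `COc1ccc(Cn2nc(Nc3cc(C)[nH]n3)c3ccccc3c2=O)cc1` gives 1200 nM. Compound 4 `Cc1cc(Nc2nn(Cc3ccc([N+](=O)[O-])cc3)c(=O)c3ccccc23)n[nH]1` carries 4-nitrophenyl in place of hydrogen on a saturated chain carbon bound to an aromatic nitrogen. The closest measured step is the reverse of a 4.3-fold higher number from compound 2 to compound 3 (0.64 log units; beyond the scatter), where removing an aryl group from that same chain carbon raised the number; a 7.4-fold higher number from compound 1 to compound 3 (0.87 log units; beyond the scatter) points the same way, while a 1.7-fold higher number from compound 1 to compound 2 (0.23 log units; within the scatter) shows an aryl and a benzyl group giving similar numbers. Compound 4 is therefore expected to show a modest drop in this assay, a 3.7-fold lower number from compound 3 to compound 4 (0.57 log units; beyond the scatter), landing near the range of compound 2. Compound 4 is estimated at 1400 nM, between 500 nM and 4000 nM.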

Compound 4, half-maximal inhibitory concentration: 1400 nM
For compound 4 middle estimate and measured number coincide at the digits printed; low and high end bracket the measured number.
By their numbers in this assay, from the lowest: compounds 1, 2 and 4 (each within the scatter of the next); then compound 3.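

In this assay the gain from an aryl group on the saturated chain carbon bound to an aromatic nitrogen is not tied to methoxy, since 4-nitrophenyl in place of hydrogen gives a 3.7-fold lower number from compound 3 to compound 4 (0.57 log units; beyond the scatter). Nitro in place of methoxy on an aromatic carbon gives a 1.2-fold higher number from compound 2 to compound 4 (0.07 log units; within the scatter), so these two groups cannot be told apart here. No measurement offered accounts for either step. As far as these compounds go, whether an amine or a carboxylic acid on that aromatic carbon would keep the number in this range remains open, as does the effect of a longer chain on the aromatic nitrogen.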